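The source may hold more compounds than are shown below. What is called first, only, known or untested is meant among the compounds shown, and "the series" means these compounds.

Of the compounds shown here, three built on one shared core have been measured in an ADME assay on microsomes from liver (Rattus norvegicus) for metabolic stability, with a stated time of 30 min; on this read-out lower numbers stand for slow clearance and higher numbers for fast clearance. Compound 1 `Cn1cc(C(=O)Nc2ccc(-c3ccccc3)c(C(F)(F)F)c2)c(=O)c2ccccc21` carries a phenyl group; in this assay compound 1 gives < 14 uL/min, which is a limit of the assay and not a number (the limit of < 14 uL/min in this assay, at which 1 of the 3 values shown sits). Compound 2 `Cn1cc(C(=O)Nc2ccc(-c3cccnc3)c(C(F)(F)F)c2)c(=O)c2ccccc21` carries pyridin-3-yl at the same aromatic carbon, and in this assay compound 2 gives 18 uL/min. Compound 3 `Cn1cc(C(=O)Nc2ccc(-c3ccncc3)c(C(F)(F)F)c2)c(=O)c2ccccc21` carries pyridin-4-yl there, and in this assay compound 3 gives 44 uL/min, the highest of the two plain numbers, with compound 2 as its nearest neighbour. Across the set the steps are an at least 1.2-fold higher number from compound 1 to compound 2 (0.10 log units; that floor lies within the scatter), an at least 3.1-fold higher number from compound 1 to compound 3 (0.49 log units; beyond the scatter) and a 2.4-fold higher number from compound 2 to compound 3 (0.39 log units; beyond the scatter). Compound 4 `Cn1cc(C(=O)Nc2ccc(-c3ccccn3)c(C(F)(F)F)c2)c(=O)c2ccccc21` differs from compound 3 in a single way: pyridin-2-yl in place of pyridin-4-yl on an aromatic carbon. Within the data shown here, the steps that bear on this change are the two leading into compound 3, which show that shifting the ring nitrogen from one position to another can move the number by a modest amount in this assay. Shifting it once more, to pyridin-2-yl, is therefore expected to move the number back toward the values of compounds 1 and 2 rather than beyond compound 3. The expected step is a 2.0-fold lower number from compound 3 to compound 4 (0.30 log units; within the scatter). For compound 4 in this assay the estimate is 22 uL/min, with a likely range from 10 uL/min to 45 uL/min.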

Compound 4, intrinsic clearance in a liver preparation (reported as CLH), per the amount of preparation that the assay uses: < 14 uL/min
Compound 4: no number, only a limit; the forecaster's own chance of this, stated with the estimate: 20%; middle value at least 1.5-fold (0.19 log units) away from the limit.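

Compound 4 gives a limit of the assay and not a number: the limit of < 14 uL/min in this assay, at which 2 of the 4 values shown sit.

Moving the ring nitrogen to pyridin-2-yl, on the aromatic carbon ortho to a trifluoromethyl group, gives an at least 3.1-fold lower number from compound 3 to compound 4 (0.49 log units; beyond the scatter), so a second nitrogen shift at this position also produces a change that exceeds the scatter, and the earlier compounds had shown only one such shift, a 2.4-fold higher number from compound 2 to compound 3 (0.39 log units; beyond the scatter). The other new comparison gives an at least 1.2-fold lower number from compound 2 to compound 4 (0.10 log units; that floor lies within the scatter), a floor that does not separate these two compounds. Compound 3, with pyridin-4-yl, is now the only compound in the set whose steps to all three others lie beyond the scatter in this assay, which makes the higher number specific to that one nitrogen position among the rings shown.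

As far as these compounds go, the step between compound 1 and compound 4 cannot be read, since both are limits, and how far either compound lies under that limit stays unknown. The compounds shown also leave open how this read-out would respond to a group such as an amine or a carboxylic acid on the pyridin-2-yl ring, or to a saturated ring such as piperidine at this carbon.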